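From Cyclobutyl Ether to Free Hydroxy on a Shared Core

The compounds below may be only part of what the source reports. "The series", "measured", "known", "first", "only" and "open" are said of these compounds alone.

Compound 2 `NC(=O)c1ccc(-c2cccnc2)cc1OC1CCC1` and compound 1 `COc1cncc(-c2ccc(C(N)=O)cc2)c1` share the same core, an amide-bearing benzene joined to a pyridine, and differ only in how the oxygen and methoxy groups are placed. In an assay on cells for inhibition of MAP kinase-interacting serine/threonine-protein kinase 1 (Homo sapiens), read by mobility shift assay, with stated times of 10 min and 60 min, in the presence of a further agent that is not named here (a lower number here means a stronger inhibitor, a higher number a weaker inhibitor), compound 2 gives 1900 nM. In this assay compound 1 gives 3000 nM. Compound 2 holds the lowest of the two numbers, but its gap to compound 1 lies within the usual scatter, so the two cannot be told apart.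

Compound 3 `NC(=O)c1ccc(-c2cccnc2)cc1O` differs from compound 2 in one place: hydrogen in place of cyclobutyl on an oxygen on an aromatic ring. Going by the values given here, no measured pair of compounds covers this change, so nothing measured here shows how large such a step is. The step of a 2.6-fold higher number from compound 2 to compound 3 (0.42 log units; beyond the scatter) is expected to be a moderate rise in the number, toward a weaker inhibitor, though it could still fall within the scatter. Compound 3 is estimated at 5000 nM, with a range from 1200 nM to 20000 nM.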

Compound 3, half-maximal inhibitory concentration: 4300 nM
Beside the measured number, compound 3's estimate is 1.2-fold (0.07 log units) above it; low and high end bracket the measured number.
By their numbers in this assay, from the lowest: compounds 2, 1 and 3 (each within the scatter of the next, the first and the last beyond it).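

In this assay, going by these compounds alone, the change from cyclobutyloxy to hydroxy brings a 2.3-fold higher number from compound 2 to compound 3 (0.35 log units; beyond the scatter) and gives the first step here that can be read as one change in one place. It shows that the group on this oxygen does affect the number: with the cyclobutyl gone the number rises beyond the scatter, toward a weaker inhibitor, though the step is modest. Nothing available here accounts for the size or the direction of this step.

On these data alone, whether a longer chain on this oxygen, or an amine in its place, would lower the number or raise it remains open. Also open, as far as these compounds go, is whether the four-membered ring itself matters, or whether an open chain of carbon on the oxygen would give the same number.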